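The compounds below may be only part of what the source reports. "The series", "measured", "known", "first", "only" and "open" are said of these compounds alone.

In a functional assay on CEM-DNR-bulk cells (Homo sapiens), read by MTT assay, with a stated time of 72 h (a higher number here means a weaker inhibitor, a lower number a stronger inhibitor), compound 2 `CNc1ncnc2c1c(-c1ccccc1)cn2[C@@H]1O[C@H](CO)[C@@H](O)[C@H]1O` reads > 20000 nM, which is a limit and not a number. Compound 1 `CNc1ncnc2c1c(-c1ccco1)cn2[C@@H]1O[C@H](CO)[C@@H](O)[C@H]1O` reads > 20000 nM, also a limit. Within the data shown here, the one measured step, a step that the two limits leave unreadable from compound 1 to compound 2, offers no size to carry forward, and the limit of > 20000 nM in this assay, at which 2 of the 2 values shown sit, is all there is to go on. Compound 3 `CNc1ncnc2c1c(-c1cc3ccccc3o1)cn2[C@@H]1O[C@H](CO)[C@@H](O)[C@H]1O` brings (1-benzofuran-2-yl in place of phenyl on an aromatic carbon), that is, 1-benzofuran-2-yl in place of phenyl on an aromatic carbon. The expected change in this assay is therefore a number no higher from compound 2 to compound 3 (the limit leaves the size open), nothing beyond the scatter. Compound 3 is expected at 20000 nM, within an estimated range of 8000 nM to 40000 nM.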

Compound 3, half-maximal inhibitory concentration: > 20000 nM
Compound 3 was reported as a limit; the forecaster's own chance of this, stated with the estimate: 80%; the middle value sits exactly at the limit.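

Among these compounds, no step among compound 1, compound 2 and compound 3 can be read, because each result is a limit and not a number: the limit of > 20000 nM in this assay, at which 3 of the 3 values shown sit. On these data alone, how the furan-2-yl, phenyl and 1-benzofuran-2-yl groups truly compare in this assay stays open.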